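A few compounds are considered here, and "the series" means these few. Any claim that something is new, unique, unknown or untested is made for them only; others in the source may bear on it.

Within the data shown here, compound 2 `O=c1c(C2N=C(c3ccccc3)SS2)coc2cc(Cl)c(Cl)cc12` gives the higher of the two numbers known so far in a functional assay on COLO 205 cells (Homo sapiens) for inhibition, read by sulforhodamine B assay, with a stated time of 48 h, tested at 100 uM; on this read-out higher numbers stand for more inhibition of growth at the one concentration tested and lower numbers for less inhibition of growth: compound 2 gives 50%, while compound 1 `O=c1c(C2N=C(c3ccccc3)SS2)coc2ccc(Cl)cc12` gives 12%. Among the measured compounds shown here, the one step measured between them, a number 38 percentage points higher from compound 1 to compound 2 (beyond the scatter), is the only comparison available. Compound 3 `O=c1c(C2N=C(c3ccccc3)SS2)coc2cc(Cl)ccc12` has not yet been measured; it differs from compound 2 by hydrogen in place of chloro on an aromatic carbon, so that the chloro which compound 1 also carries is gone, and only the chloro that entered in going from compound 1 to compound 2 remains. The measured step bears on this change in reverse: taking away one of two chloro groups is expected to lower the number in this assay, by a step of a size like the one already seen, though at a different carbon. Compound 3 is therefore estimated to give 25%, within a range of 5% to 50%, which means an expected step of a number 25 percentage points lower from compound 2 to compound 3 (beyond the scatter).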

Compound 3, percent growth inhibition at one concentration: 57%
Compound 3: the middle estimate sits 32 percentage points below what was measured, and the stated range ends below it.
By their numbers in this assay, from the lowest: compound 1; then compounds 2 and 3 (each within the scatter of the next).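

Going a number 7 percentage points higher from compound 2 to compound 3 (within the scatter) in this assay shows that the chloro on this carbon, ortho to a chloro group in compound 2, can give way to hydrogen without a change that can be told from the scatter. Among these compounds, the two chloro groups of compound 2 therefore do not count alike: the one that entered a number 38 percentage points higher from compound 1 to compound 2 (beyond the scatter) goes with a large step, while the one lost here goes with none that can be read. No measurement given here bears on why the two carbons differ.

The compounds shown leave open whether this carbon accepts anything other than chloro or hydrogen, such as a methoxy group, an amine or a carboxylic acid. They also leave open how the phenyl group on the shared core bears on the number, for instance if it carried a chloro or a methoxy group.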